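The source may hold more compounds than are shown below. What is called first, only, known or untested is meant among the compounds shown, and "the series" means these compounds.

Measured in an ADME assay on cells (Hepatocyte, Mus musculus) for cytotoxicity, read by MTT assay, with a stated time of 24 h; a higher number here means that more compound is tolerated, a lower number that less compound is tolerated:
- Compound 1 `O=S(=O)(c1ccc(Br)cc1)n1c(-c2cn(-c3ccccc3)nc2-c2ccc(F)cc2)nc2ccccc21`: > 300000 nM
- Compound 2 `O=S(=O)(c1ccc(Cl)cc1)n1c(-c2cn(-c3ccccc3)nc2-c2ccc(C(F)(F)F)cc2)nc2ccccc21`: 173000 nM

Among the compounds with values here, compound 2, with 173000 nM, holds the only true number in this assay. Compound 1 reads > 300000 nM, which is a limit of the assay and not a number. These two compounds differ in more than one place, so no single change can be read from them.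

Compound 3 `O=S(=O)(c1ccc(Br)cc1)n1c(-c2cn(-c3ccccc3)nc2-c2ccc(C(F)(F)F)cc2)nc2ccccc21` has not yet been measured. It differs from compound 2 in one place: bromo in place of chloro on an aromatic carbon, para to a large group (bromo in place of chloro on an aromatic carbon). Within the data shown here, with no measured single-change step as a guide, the expected step of a 1.1-fold higher number from compound 2 to compound 3 (0.04 log units; within the scatter) is none beyond the usual scatter. For compound 3 the estimated value is 190000 nM, with an expected range from 105000 nM to 320000 nM.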

Compound 3, half-maximal cytotoxic concentration: 167000 nM
Compound 3: middle estimate off by 1.1-fold (0.06 log units), on the high side; the range from low to high includes it.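

In this assay, within the data shown here, the swap from 4-chlorophenyl to 4-bromophenyl gives the first single change that can be read between true numbers: a 1.0-fold lower number from compound 2 to compound 3 (0.02 log units; within the scatter), so with trifluoromethyl on the other aryl ring, these two halogens cannot be told apart at this position. A second single change, trifluoromethyl in place of fluoro, can be read only as a floor: an at least 1.7-fold lower number from compound 1 to compound 3 (0.25 log units; that floor lies within the scatter), and because that floor lies within the scatter, it shows no real change. Compound 1 holds a limit and not a number: the limit of > 300000 nM in this assay, at which 1 of the 3 values shown sits.

Going by these compounds, the true size of the step from fluoro to trifluoromethyl stays open, since one end of it is only a limit. Also open, on these data alone, is whether a quite different group at the halogen position, such as an amine or a carboxylic acid, would shift the number beyond the scatter.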